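Chain length on the phenoxy side, from compound 2 to compound 4

The source may hold more compounds than are shown below. What is called first, only, known or untested is meant among the compounds shown, and "the series" means these compounds.

In an assay on isolated protein for inhibition of malate dehydrogenase, mitochondrial (Homo sapiens), with a stated time of 30 min (on this read-out higher numbers stand for weaker inhibition and lower numbers for stronger inhibition), compound 1 `CC(C)(C)CC(C)(C)c1ccc(OCC(=O)Nc2ccc(C(F)(F)F)cc2)cc1` gives 1530 nM. Compound 3 `COC(=O)c1ccc(O)c(NC(=O)CCCOc2ccc(C(C)(C)CC(C)(C)C)cc2)c1` differs from compound 1 in several places. In this assay compound 3 gives 1110 nM. Compound 2 `COC(=O)c1cccc(NC(=O)COc2ccc(C)cc2)c1` gives only a limit in this assay, > 40000 nM. Compound 2 therefore stands at the weak end of the numbers shown, sitting at the limit (the limit of > 40000 nM in this assay, at which 1 of the 3 values shown sits), while the two other compounds sit far below it with measurable inhibition.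

Compound 4 `CCCCCc1ccc(OCC(=O)Nc2cccc(C(=O)OC)c2)cc1` differs from compound 2 in one place: butyl in place of hydrogen on a saturated chain carbon bound to an aromatic carbon. Within the data shown here, no measured pair in the set shows this step, so its size cannot be read from the data. Since compound 1 gives 1530 nM and compound 3 gives 1110 nM with a large alkyl group on the phenoxy ring, whereas compound 2 with a methyl group gives no measurable value, a step toward stronger inhibition beyond the usual scatter is expected for compound 4. Compound 4 is estimated at 8000 nM, within 2000 nM to 40000 nM. The step of an at least 5.0-fold lower number from compound 2 to compound 4 (0.69 log units; beyond the scatter) is the expected one, with some chance that compound 4 also returns only a limit.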

Compound 4, half-maximal inhibitory concentration: > 40000 nM
Compound 4 ended at the assay's limit; the forecaster's own chance of this, stated with the estimate: 25%; middle value at least 5.0-fold (0.69 log units) away from the limit.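

Compound 2 and compound 4 both return only a limit in this assay, so no size can be read for the change from methyl to pentyl: the limit of > 40000 nM in this assay, at which 2 of the 4 values shown sit.

The compounds shown leave open whether any alkyl group in that place brings the core of compound 2 into the measurable range.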